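Swapping an Amino Group for Methyl on a Pyrimidine Core

The compounds below may be only part of what the source reports. "The series", "measured", "known", "first", "only" and "open" are said of these compounds alone.

Measured compounds:
Compound 1, `C#CCOc1ccc(-c2cc(-c3cccc(OCC#C)c3)nc(N)n2)cc1`: 24100 nM
Compound 2, `C#CCOc1ccc(-c2cc(-c3ccccc3OCC#C)nc(C)n2)cc1`: 23200 nM

Both measured compounds were tested in an assay on BTI-TN-5B1-4 cells for inhibition of Amine oxidase [flavin-containing] A (Homo sapiens), read by fluorescence and Amplex Red, using microsomes, with a stated time of 30 min; on this read-out higher numbers stand for weaker inhibition and lower numbers for stronger inhibition. Compound 1 gives 24100 nM there, and compound 2 gives 23200 nM. The two numbers sit so close together that the gap between them is within the usual scatter of repeated measurements, so neither compound can be called the stronger or weaker inhibitor; compound 1 simply stands at one end of this pair of nearly equal values.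

Compound 3, `C#CCOc1ccc(-c2cc(-c3cccc(OCC#C)c3)nc(C)n2)cc1`, has not yet been measured. It differs from compound 1 in one place: methyl in place of amino on an aromatic carbon. Compound 2 already carries a methyl group at this position, though with one of its side chains attached differently, and it behaves much like compound 1. On that basis the step from compound 1 to compound 3 is expected to be small, with no clear direction beyond the scatter, a 1.1-fold lower number from compound 1 to compound 3 (0.04 log units; within the scatter). Compound 3 is therefore estimated to show about 22000 nM in this assay, with a plausible range from 8000 nM to 60000 nM.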

Compound 3, half-maximal inhibitory concentration: 21100 nM
The estimate for compound 3 lay 1.0-fold (0.02 log units) above the measured number, within the range that was stated.
By their numbers in this assay, from the lowest: compounds 3, 2 and 1 (each within the scatter of the next).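

Compounds 1 and 2 differ in more than one place, so that pair could not isolate the change at this position, whereas compounds 1 and 3 differ only there. On the aromatic carbon between two ring nitrogen atoms, methyl in place of amino gives a 1.1-fold lower number from compound 1 to compound 3 (0.06 log units; within the scatter) in this assay, so this direct comparison shows no readable effect of the exchange. The amino group counts one hydrogen-bond donor and one hydrogen-bond acceptor and methyl counts neither, yet this difference in the counts comes with no separation between the two numbers, and nothing measured here offers an explanation for that.

Among these compounds, this single pair covers only two small groups, so it remains open whether a larger or differently built group at the same carbon, such as a carboxylic acid, a methoxy group or a longer chain, would move the number beyond the usual scatter. As far as these compounds go, it also remains open whether amino and methyl would stay equally matched on a core whose side chains are attached differently, as they are in compound 2.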